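A few compounds are considered here, and "the series" means these few. Any claim that something is new, unique, unknown or untested is made for them only; others in the source may bear on it.

Compound 2 `Cc1cccc(Cc2cnc(CCc3ccc(-c4ccccc4C(=O)O)cc3)[nH]2)c1` carries a 3-methylphenyl group on a saturated chain carbon bound to an aromatic carbon of the shared core. In an in vitro functional assay on cells for agonist activity at Bombesin receptor subtype-3 (Homo sapiens), read by luminescence and calcium flux (on this read-out higher numbers stand for an effect only at larger amounts of compound and lower numbers for an effect already at smaller amounts), compound 2 gives 4310 nM, the highest of the two numbers measured; its nearest neighbour is compound 1 `O=C(O)c1ccccc1-c1ccc(CCc2ncc(CC3CCC3)[nH]2)cc1`, which in this assay gives 588 nM. Going by the values given here, the only measured step, a 7.3-fold higher number from compound 1 to compound 2 (0.87 log units; beyond the scatter), shows that replacing cyclobutyl by 3-methylphenyl at this position raised the number well beyond the scatter.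

Compound 3 `CC(C)CCc1cnc(CCc2ccc(-c3ccccc3C(=O)O)cc2)[nH]1` has not been measured. Its difference from compound 2 is isobutyl in place of 3-methylphenyl on a saturated chain carbon bound to an aromatic carbon. This change runs in the opposite sense to the measured one: an aromatic ring leaves and a short branched chain enters at the same saturated chain carbon, and isobutyl resembles cyclobutyl of compound 1 more than it resembles 3-methylphenyl of compound 2. Because of a 7.3-fold higher number from compound 1 to compound 2 (0.87 log units; beyond the scatter), a lower number is expected for compound 3, with a step of about a 4.3-fold lower number from compound 2 to compound 3 (0.63 log units; beyond the scatter). Compound 3 is therefore estimated at 1000 nM, with a range from 300 nM to 4000 nM.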

Compound 3, half-maximal effective concentration: 119 nM
Beside the measured number, compound 3's estimate is 8.4-fold (0.92 log units) above it, outside the stated range (below it).
By their numbers in this assay, from the lowest: compound 3; then compound 1; then compound 2.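

In this assay, isobutyl in place of 3-methylphenyl on this saturated chain carbon gives a 36-fold lower number from compound 2 to compound 3 (1.56 log units; beyond the scatter), so the number at this position can fall well past the level set by the cyclobutyl group of compound 1. The position also distinguishes between the two groups without an aromatic ring, which the earlier pair could not show: isobutyl in place of cyclobutyl gives a 4.9-fold lower number from compound 1 to compound 3 (0.69 log units; beyond the scatter), so the loss of the aromatic ring does not by itself set the number, and the open-chain isobutyl gives the lowest number of the three groups. Nothing available here explains why these three groups fall in this order.

The three compounds leave open whether a longer chain, such as n-hexyl, would lower the number further or raise it again, and whether a cyclohexyl ring or an unsubstituted phenyl would follow the cyclobutyl or the 3-methylphenyl group. They also leave open how an amine or a hydroxyl group at the end of the isobutyl chain would read, since every group shown at this position is made of carbon only.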